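The compounds below may be only part of what the source reports. "The series", "measured", "known", "first", "only" and "open" are said of these compounds alone.

Working notes on the series. Compound 1 `C[C@@H](Cn1ccc(-c2ccc(C#N)c(Cl)c2)n1)NC(=O)c1ccccc1` carries the shared core with a benzoyl on the amine nitrogen. In an ADME assay on PC-3 cells (Homo sapiens) for cytotoxicity, read by CCK-8 assay, with a stated time of 6 days (on this read-out higher numbers stand for weaker inhibition and lower numbers for stronger inhibition), compound 1 gives > 30000 nM, which is a limit of the assay and not a number. Compound 2 `C[C@@H](Cn1ccc(-c2ccc(C#N)c(Cl)c2)n1)NC(=O)c1cccc(OCC(O)CO)c1` carries 2,3-dihydroxypropoxy in place of hydrogen on an aromatic carbon. In this assay compound 2 gives > 30000 nM, again a limit rather than a number. The step that the two limits leave unreadable from compound 1 to compound 2 is therefore of unreadable size. Compound 3 `C[C@@H](Cn1ccc(-c2ccc(C#N)c(Cl)c2)n1)Nc1ccc2cnccc2c1` has no result in this assay, its entry reading "not determined" (no result reported). The measured picture is summed up by the limit of > 30000 nM in this assay, at which 2 of the 3 values shown sit; compound 1 stands at that limit, with nothing resolved around it.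

Compound 4 `C[C@@H](Cn1ccc(-c2ccc(C#N)c(Cl)c2)n1)Nc1ncnc2nc[nH]c12` is the next compound to be measured. It differs from compound 1 by a group of 9 heavy atoms (5 carbon, 4 nitrogen; one five-membered aromatic ring with 2 hetero atoms, one six-membered aromatic ring with 2 hetero atoms) in place of a group of 8 heavy atoms (7 carbon, 1 oxygen; one six-membered aromatic ring of carbon only), on an amine nitrogen. For the measured compounds named here, no measured step bears on this change: the one step known, a step that the two limits leave unreadable from compound 1 to compound 2, is unreadable at both ends and alters a different group, and compound 3 contributes no number at all. With no anchor for a direction, the estimated step of a number no higher from compound 1 to compound 4 (the limit leaves the size open) for compound 4 means no change beyond the scatter. Compound 4 is therefore estimated at 30000 nM, within a range from 8000 nM to 60000 nM.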

Compound 4, half-maximal inhibitory concentration: 14100 nM
For compound 4 the middle estimate is 2.1-fold (0.33 log units) above the measured one; the range from low to high includes it.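

For the compounds shown here, replacing benzoyl on the amine nitrogen with the group of one five-membered and one six-membered aromatic ring, each with 2 hetero atoms, gives an at least 2.1-fold lower number from compound 1 to compound 4 (0.32 log units; beyond the scatter), the first step that can be read. It shows that a change at this place can bring a number within the range of this assay, which the 2,3-dihydroxypropoxy change on the benzoyl ring did not show, as the step from compound 1 to compound 2 cannot be read. The step to compound 4 gives only a minimum size, because the series still rests largely on a limit rather than on numbers: the limit of > 30000 nM in this assay, at which 2 of the 4 values shown sit.

The compounds shown leave open which part of the entering group carries the step, whether the five-membered ring, the six-membered ring, or the loss of the carbonyl, and compound 3, with a different group on the same nitrogen, adds no number. They also leave open how a single six-membered aromatic ring with 2 hetero atoms, or an amine or a carboxylic acid attached to the entering group, would read at this place.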